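Dropping the acetamido group: what compound 3 may show

A few compounds are considered here, and "the series" means these few. Any claim that something is new, unique, unknown or untested is made for them only; others in the source may bear on it.

Measured so far:
compound 1 `COc1ccc(/C=C/C(=O)c2ccc(NC(C)=O)c(-c3ccc(F)cc3)c2)cc1OC` — 2650 nM
compound 2 `COc1ccccc1/C=C/C(=O)c1cccc(-c2cccc(F)c2)c1` — 35300 nM

In an assay on A549 cells for inhibition of transcription factor p65 (Homo sapiens), read by fluorescence, with a stated time of 2 h (on this read-out lower numbers stand for stronger inhibition and higher numbers for weaker inhibition), compound 1 gives the lower of the two numbers; compound 2 sits far above it, beyond the scatter. Compound 3 `COc1ccc(/C=C/C(=O)c2cccc(-c3ccc(F)cc3)c2)cc1OC` is not yet measured. It differs from compound 1 by hydrogen in place of acetamido on an aromatic carbon. Among the measured compounds shown here, no single-change step is available to size this, so a loss is expected in this assay, giving an expected step of a 3.0-fold higher number from compound 1 to compound 3 (0.48 log units; beyond the scatter) for compound 3. Compound 3 is therefore estimated at 8000 nM, within 2500 nM to 30000 nM.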

Compound 3, half-maximal inhibitory concentration: > 50000 nM
Compound 3: no number, only a limit; the forecaster's own chance of this, stated with the estimate: 5%; at least 6.2-fold (0.79 log units) between middle value and limit.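

In this assay, hydrogen in place of acetamido on the aromatic carbon ortho to a 4-fluorophenyl group gives an at least 18-fold higher number from compound 1 to compound 3 (1.27 log units; beyond the scatter). Among the compounds shown here, this is the first single-change step here, and it shows that this position is not indifferent to what it carries. The value of compound 3 is a limit and not a number: the limit of > 50000 nM in this assay, at which 1 of the 3 values shown sits.

The compounds shown leave open whether a free amine or a longer amide chain at this position would keep up with acetamido. They also leave open whether a methoxy group there would do the same.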